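This account rests on a few compounds, and the source may have more. Where it says the series, first, only, none or still open, it means among the compounds named here.

In a functional assay on brain (Rattus norvegicus, strain Wistar) for inhibition (a lower number here means a stronger inhibitor, a higher number a weaker inhibitor), compound 1 `Cc1[nH]c(=O)n(C)c1-c1ccc(CC(C)C)cc1` gives 7800 nM and compound 2 `CCCc1ccc(-c2c(C)[nH]c(=O)n2C2CCCCC2)cc1` gives 13900 nM and these two values lie within the usual scatter of each other. Compound 3 `Cc1[nH]c(=O)n(C2CCCCC2)c1-c1ccc(CC(C)C)cc1` differs from compound 2 by methyl in place of hydrogen on a saturated chain carbon bound to two saturated chain carbons with a methyl in place of hydrogen on a saturated chain carbon bound to two saturated chain carbons, which turns propyl to isobutyl. Among the compounds with values here, no measured pair shows this change alone, and no shift beyond the scatter is expected. The estimated step of a 1.4-fold lower number from compound 2 to compound 3 (0.14 log units; within the scatter) is therefore small. For compound 3 the expected value is 10000 nM with an estimated range from 4000 nM to 25000 nM as its likely span.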

Compound 3, half-maximal inhibitory concentration: 10900 nM
Estimate against measurement, compound 3: 1.1-fold (0.04 log units) below; measured number inside the range.
By their numbers in this assay, from the lowest: compounds 1, 3 and 2 (each within the scatter of the next).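

Turning propyl into isobutyl gives a 1.3-fold lower number from compound 2 to compound 3 (0.11 log units; within the scatter), so the added methyl on this chain carbon brings no readable shift in this assay. Cyclohexyl in place of methyl on the aromatic nitrogen gives a 1.4-fold higher number from compound 1 to compound 3 (0.15 log units; within the scatter), so this swap, read alone for the first time, brings no readable shift either. Nothing available explains why either change is tolerated. Still open, as far as these compounds go, is whether a carboxylic acid or an amine at the end of the chain, or a longer chain, would move the number beyond the scatter.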